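Hydroxy added to the bromophenyl arm of compound 1

The compounds below may be only part of what the source reports. "The series", "measured", "known", "first", "only" and "open" are said of these compounds alone.

compound 1 `O=C(N/N=C/c1cccc(Br)c1)Nc1ccc(Oc2ccnc3[nH]ccc23)c(F)c1`: 49 nM
compound 2 `O=C(N/N=C/c1ccc(F)cc1)Nc1ccc(Oc2ccnc3[nH]ccc23)c(F)c1`: 800 nM
compound 3 `O=C(N/N=C/c1cccc([N+](=O)[O-])c1)Nc1ccc(Oc2ccnc3[nH]ccc23)c(F)c1`: "not active" (no number reported)

In a functional assay on MCF7 cells (Homo sapiens) for antiproliferative activity, read by MTT assay, with a stated time of 72 h (on this read-out lower numbers stand for stronger inhibition and higher numbers for weaker inhibition), compound 1 gives 49 nM, the lowest of the two numbers reported. Compound 2 gives 800 nM, and the step of a 16-fold higher number from compound 1 to compound 2 (1.21 log units; beyond the scatter) shows that the aryl group on the hydrazone carbon governs the read-out strongly. Compound 3 is reported as "not active" (no number reported), a further sign of this sensitivity, though without a number.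

Compound 4 `O=C(N/N=C/c1ccc(O)c(Br)c1)Nc1ccc(Oc2ccnc3[nH]ccc23)c(F)c1` is not yet measured. It differs from compound 1 by hydroxy in place of hydrogen on an aromatic carbon, that is, 3-bromophenyl to 3-bromo-4-hydroxyphenyl. Among the compounds with values here, no measured step adds a hydroxy while keeping the bromo group, so nothing bears directly on it; the one measured step, a 16-fold higher number from compound 1 to compound 2 (1.21 log units; beyond the scatter), was large and in the weaker direction, and compound 3 shows that another substitution on this ring removes activity. Compound 4 is therefore expected to give a somewhat higher number than compound 1, a 2.4-fold higher number from compound 1 to compound 4 (0.39 log units; beyond the scatter), with wide uncertainty. The estimate for compound 4 in this assay is 120 nM, between 30 nM and 600 nM.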

Compound 4, half-maximal inhibitory concentration: 8230 nM
Compound 4: middle estimate off by 69-fold (1.84 log units), on the low side; the whole stated range lies below it.
By their numbers in this assay, from the lowest: compound 1; then compound 2; then compound 4.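

In this assay, within the data shown here, a single hydroxy on the 3-bromophenyl arm, ortho to the bromo group and para to a large group, gives a 170-fold higher number from compound 1 to compound 4 (2.23 log units; beyond the scatter), so this ring position, untested by the earlier compounds, is far from indifferent to a small addition. Keeping the bromo group does not preserve the read-out either: the 3-bromo-4-hydroxyphenyl arm also gives a 10-fold higher number from compound 2 to compound 4 (1.01 log units; beyond the scatter), and the 4-fluorophenyl arm, with no bromo group at all, holds the lower number. No measurement in hand accounts for this loss.

As far as these compounds go, whether the loss follows the hydroxy itself or any group placed here remains open; a methoxy or an amine at this position would help to separate the two. Also open, from the compounds shown here alone, is whether hydroxy on the ring without the bromo group gives a similar loss.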